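From 3-bromophenyl to 2-fluorophenyl on the shared core

The source may hold more compounds than are shown below. What is called first, only, known or untested is meant among the compounds shown, and "the series" means these compounds.

In an ADME assay on HEK293 cells (Homo sapiens) for cytotoxicity, read by MTT assay, with a stated time of 72 h (a higher number here means a weaker inhibitor, a lower number a stronger inhibitor), compound 1 `O=C(CN1CCN(C(=O)c2ccccc2)CC1)N1CCN(CCCc2c[nH]c3ccccc23)CC1` gives > 200000 nM, which is a limit of the assay and not a number. Compound 2 `Cc1ccc(C(=O)N2CCN(CC(=O)N3CCN(CCCc4c[nH]c5ccccc45)CC3)CC2)cc1` gives 159000 nM, and compound 3 `O=C(CN1CCN(C(=O)c2cccc(Br)c2)CC1)N1CCN(CCCc2c[nH]c3ccccc23)CC1` gives 80700 nM, so compound 3 stands level with compound 2 within the scatter, at a 2.0-fold lower number from compound 2 to compound 3 (0.29 log units; within the scatter). Compound 4 `O=C(CN1CCN(C(=O)c2ccccc2F)CC1)N1CCN(CCCc2c[nH]c3ccccc23)CC1` has 2-fluorophenyl in place of 3-bromophenyl on a carbonyl carbon. Within the data shown here, its fluoro group has no measured precedent here. Bromo in place of hydrogen gave an at least 2.4-fold lower number from compound 1 to compound 3 (0.39 log units; beyond the scatter), and methyl in place of hydrogen gave an at least 1.2-fold lower number from compound 1 to compound 2 (0.09 log units; that floor lies within the scatter). Losing the bromo group may undo part of that first step, so the expected step is a 1.9-fold higher number from compound 3 to compound 4 (0.27 log units; within the scatter), towards a higher number. Compound 4 is estimated at 150000 nM, with an expected range of 80000 nM to 280000 nM.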

Compound 4, half-maximal inhibitory concentration: 133000 nM
Compound 4: the middle estimate sits 1.1-fold (0.05 log units) above what was measured; the measured number falls inside the stated range.
By their numbers in this assay, from the lowest: compounds 3, 4 and 2 (each within the scatter of the next). At a limit, above all of these: compound 1.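

The swap to 2-fluorophenyl on the carbonyl carbon gives a 1.6-fold higher number from compound 3 to compound 4 (0.22 log units; within the scatter), and the comparison with 4-methylphenyl gives a 1.2-fold lower number from compound 2 to compound 4 (0.08 log units; within the scatter), so this assay does not separate these three compounds. Fluoro in place of hydrogen gives an at least 1.5-fold lower number from compound 1 to compound 4 (0.17 log units; that floor lies within the scatter), the first fluoro step shown at this carbonyl group. Compound 1 stands at a limit and not a number, so the true size of that step stays unknown: the limit of > 200000 nM in this assay, at which 1 of the 4 values shown sits.

Compound 4 changes both the halogen and its printed ring position, so the two effects cannot be told apart. Going by these compounds, whether an amine or a carboxylic acid on this phenyl ring would give a step beyond the scatter remains open.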